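The source may report more compounds than this note shows. Statements on the series, on what has been measured and on what is new or still open speak of the compounds shown alone.

Measured compounds and values:
- compound 1, `CCNC(=O)OC[C@H]1OC(n2cnc3c(NC4CCOC4)ncnc32)[C@H](O)[C@@H]1O`: in an assay on DDT1 cells (Cricetulus griseus) for binding affinity to adenosine receptor A1 (Homo sapiens), read by radioligand binding (on this read-out higher numbers stand for weaker inhibition and lower numbers for stronger inhibition), compound 1 gives 167 nM
- compound 2, `O[C@@H]1[C@@H](CO/C(S)=N/C2CC2)OC(n2cnc3c(NC4CCOC4)ncnc32)[C@@H]1O`: compound 2 gives 157 nM
- compound 3, `O[C@@H]1[C@@H](CO/C(S)=N/Cc2ccccc2)OC(n2cnc3c(NC4CCOC4)ncnc32)[C@@H]1O`: compound 3 gives 12 nM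

Compound 3 holds the lowest number of the three. Its separation from the other two is large and beyond the scatter: a 13-fold lower number from compound 2 to compound 3 (1.12 log units; beyond the scatter) and a 14-fold lower number from compound 1 to compound 3 (1.14 log units; beyond the scatter). The two small groups on the same oxygen, by contrast, are indistinguishable here, as a 1.1-fold lower number from compound 1 to compound 2 (0.03 log units; within the scatter) lies within the scatter.

Compound 4, `CN(C)C(=S)OC[C@H]1OC(n2cnc3c(NC4CCOC4)ncnc32)[C@H](O)[C@@H]1O`, is the next case. Compared with compound 3 the change is a group of 5 heavy atoms (3 carbon, 1 nitrogen, 1 sulfur; no ring) in place of a group of 10 heavy atoms (8 carbon, 1 nitrogen, 1 sulfur; one six-membered aromatic ring of carbon only), on an oxygen on a saturated carbon. The benzyl-bearing group leaves and a small acyclic group without a ring enters, so the step runs in the opposite sense to the two large steps that led to compound 3. Compound 1 and compound 2 show that small groups at this position land in the same region of this assay, and compound 4 carries a group of that kind. The expectation is therefore a marked rise in the number, about a 13-fold higher number from compound 3 to compound 4 (1.10 log units; beyond the scatter), back toward the region of compound 1 and compound 2. For compound 4 the expected value in this assay is 150 nM, with a range of 60 nM to 400 nM.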

Compound 4, inhibition constant: 205 nM
For compound 4 the middle estimate is 1.4-fold (0.14 log units) below the measured one; the range from low to high includes it.
By their numbers in this assay, from the lowest: compound 3; then compounds 2, 1 and 4 (each within the scatter of the next).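

In this assay the cluster of small groups on this oxygen now takes in a group with no ring and no hydrogen-bond donor: there is a 1.3-fold higher number from compound 2 to compound 4 (0.12 log units; within the scatter) and a 1.2-fold higher number from compound 1 to compound 4 (0.09 log units; within the scatter) so compound 4 cannot be told apart from either. The benzyl-bearing group of compound 3 stands alone among the four compounds, and a 17-fold higher number from compound 3 to compound 4 (1.23 log units; beyond the scatter) adds a large step that ends inside that cluster. Sulfur in the group does not by itself go with a low number, since compound 3, compound 2 and compound 4 all carry it, and the large step removes the aromatic ring and the one hydrogen-bond donor together.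

Which of those two losses carries the step remains open, as does whether the low number needs the aromatic ring itself or only a larger group. A nitrogen bearing both methyl and benzyl would separate the ring from the donor, while phenethyl or a longer chain such as hexyl would test ring against size.

No supporting measurement bears on why these steps take the sizes they do.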